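The source may report more compounds than this note shows. Statements on the series, on what has been measured and on what is new or still open speak of the compounds shown alone.

Measured so far in an assay on cells for displacement of a labelled ligand from corticotropin-releasing factor receptor 1 (Homo sapiens), with a stated time of 100 min; a higher number here means a weaker inhibitor, a lower number a stronger inhibitor:
Compound 1 `CCCCN(C)Cc1c(C(F)(F)F)nc2n(-c3c(C)cc(C)cc3C)c(Cl)cn12` gives 310 nM.
Compound 2 `CCCN(Cc1ccccc1)Cc1c(C(F)(F)F)nc2n(-c3c(C)cc(C)cc3C)c(Cl)cn12` gives 170 nM.

Compound 2 and compound 1 sit within the usual scatter of each other, separated only by a 1.8-fold lower number from compound 1 to compound 2 (0.26 log units; within the scatter), so neither can be called the stronger binder. Compound 3 `Cc1cc(C)c(-n2c(Cl)cn3c(CN(C)Cc4ccco4)c(C(F)(F)F)nc23)c(C)c1` is not yet measured; it differs from compound 2 in one place: ((furan-2-yl)methyl)(methyl)amino in place of benzyl(propyl)amino on a saturated chain carbon bound to an aromatic carbon. For the measured compounds named here, the only comparable step, a 1.8-fold lower number from compound 1 to compound 2 (0.26 log units; within the scatter), also exchanged the groups on the saturated chain carbon bound to an aromatic carbon and stayed within the scatter, so in this assay no step beyond the scatter is expected in either direction. Compound 3 is therefore estimated at 250 nM, with a range of 80 nM to 800 nM, which means an expected step of a 1.5-fold higher number from compound 2 to compound 3 (0.17 log units; within the scatter).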

Compound 3, inhibition constant: 180 nM
For compound 3 the middle estimate is 1.4-fold (0.14 log units) above the measured one; low and high end bracket the measured number.
By their numbers in this assay, from the lowest: compounds 2, 3 and 1 (each within the scatter of the next).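

At this saturated chain carbon bound to an aromatic carbon, ((furan-2-yl)methyl)(methyl)amino in place of benzyl(propyl)amino gives a 1.1-fold higher number from compound 2 to compound 3 (0.02 log units; within the scatter) in this assay, so a five-membered aromatic ring with 1 hetero atom is tolerated as well as a six-membered ring of carbon only. Furan-2-yl in place of propyl gives a 1.7-fold lower number from compound 1 to compound 3 (0.24 log units; within the scatter), so this exchange also cannot be told apart from the scatter. No available evidence explains these results. All three compounds remain within the scatter of their neighbours. This place has yet to show a clear effect. A pyridine ring or a chain carrying a carboxylic acid here could still give a step beyond the scatter.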